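The compounds below may be only part of what the source reports. "The series", "measured", "known", "first", "only" and "open" are said of these compounds alone.

Notes on the series. Three compounds have numbers in a functional assay on CHO-K1 cells for antagonist activity at transient receptor potential cation channel subfamily V member 1 (Homo sapiens), read by FLIPR; on this read-out higher numbers stand for weaker inhibition and lower numbers for stronger inhibition. Compound 1 `CC(C(=O)NCc1ccc(C(F)(F)F)nc1NCC1CCN(C(=O)OC(C)(C)C)CC1)c1ccc(NS(C)(=O)=O)c(F)c1` gives 1140 nM in this assay. Compound 2 `CCCN(CCC)c1nc(C(F)(F)F)ccc1CNC(=O)C(C)c1ccc(NS(C)(=O)=O)c(F)c1` gives 14.7 nM in this assay. Compound 3 `CC(C(=O)NCc1ccc(C(F)(F)F)nc1N1CCC(Cc2cc(F)cc(F)c2)CC1)c1ccc(NS(C)(=O)=O)c(F)c1` gives 24 nM in this assay, which is the second highest of the three numbers; its nearest neighbour is compound 2, with a gap that lies within the scatter, and its furthest is compound 1, with a gap beyond the scatter. Going by the values given here, no pair of these three differs in one place only, so no single step is defined among them.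

Compound 4 `CC(C(=O)NCc1ccc(C(F)(F)F)nc1N1CCC(OC(=O)C(C)(C)C)CC1)c1ccc(NS(C)(=O)=O)c(F)c1` is not yet measured. It differs from compound 3 by ((tert-butyl)carbonyl)oxy in place of 3,5-difluorobenzyl on a saturated ring carbon. Among the compounds with values here, compound 1, the one compound here whose group on the saturated ring carries a carbonyl and oxygen, shows 1140 nM, and this is the only guide to the change. For compound 4 a step from compound 3 to compound 4 of a 5.0-fold higher number from compound 3 to compound 4 (0.70 log units; beyond the scatter) toward weaker inhibition is expected in this assay. Compound 4 is therefore estimated at 120 nM, with a range from 30 nM to 500 nM.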

Compound 4, half-maximal inhibitory concentration: 45.2 nM
For compound 4 the middle estimate is 2.7-fold (0.42 log units) above the measured one; the range from low to high includes it.
By their numbers in this assay, from the lowest: compounds 2, 3 and 4 (each within the scatter of the next, the first and the last beyond it); then compound 1.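

In this assay, ((tert-butyl)carbonyl)oxy in place of 3,5-difluorobenzyl on a saturated ring carbon, three ring bonds from the ring nitrogen, gives a 1.9-fold higher number from compound 3 to compound 4 (0.27 log units; within the scatter) and so stays within the scatter. At this position, a group with no ring and two hydrogen-bond acceptors therefore reads the same as one with a six-membered aromatic ring and none, so the aromatic ring is not required for a number in this range. Nothing measured here on either group bears on the reason for this result.

Still open, going by these compounds, is whether the carbonyl and oxygen can be dispensed with as well, as a hydroxyl or a primary amine on the same ring carbon would show. A carboxylic acid or a longer chain at this position also remains to be read in this assay before the limits of this position can be stated.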